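The source may hold more compounds than are shown below. What is called first, only, known or untested is meant among the compounds shown, and "the series" means these compounds.

Measured compounds:
Compound 1, `CCN(Cc1ccccc1)c1cccc(C(=O)N2CCc3ccc(OS(N)(=O)=O)cc3C2)c1`, 69%
Compound 2, `CN(C)CCN(Cc1ccccc1)c1cccc(C(=O)N2CCc3ccc(OS(N)(=O)=O)cc3C2)c1`, 28.6%
Compound 3, `CCCN(Cc1ccccc1)c1ccc(C(=O)N2CCc3ccc(OS(N)(=O)=O)cc3C2)cc1`, 94.3%

All three were tested in an assay on HEK293 cells for inhibition of Steryl-sulfatase (Homo sapiens), tested at 1 uM; on this read-out lower numbers stand for a weaker effect and higher numbers for a stronger effect at the one concentration tested. Compound 2 differs from compound 1 by one change, (dimethylamino in place of hydrogen on a saturated chain carbon, two bonds along the chain from a nitrogen on an aromatic ring), and the step was a number 40.4 percentage points lower from compound 1 to compound 2 (beyond the scatter). Compound 3 has the highest number of the three, and the difference between its core and the core of compound 1 is not broken down here.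

Compound 4, `CN(C)CCCN(Cc1ccccc1)c1ccc(C(=O)N2CCc3ccc(OS(N)(=O)=O)cc3C2)cc1`, has not yet been measured. It differs from compound 3 by dimethylamino in place of hydrogen on a saturated chain carbon, three bonds along the chain from a nitrogen on an aromatic ring. Among the measured compounds shown here, this is the same kind of change as the one from compound 1 to compound 2, but not the same: there the dimethylamino sits two bonds along the chain from a nitrogen on an aromatic ring, here three bonds along the chain. Because the earlier change brought a number 40.4 percentage points lower from compound 1 to compound 2 (beyond the scatter), a drop is expected here too, of roughly a number 36.3 percentage points lower from compound 3 to compound 4 (beyond the scatter), with wide uncertainty since the chain length and the core both differ. Compound 4 is therefore estimated at 58%, expected to lie between 35% and 85%.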

Compound 4, a percentage reported as inhibition, at one concentration (the size of the read-out at that concentration, not a potency): 61.6%
Estimate against measurement, compound 4: 3.6 percentage points below, within the range that was stated.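

In this assay, placing dimethylamino on the chain of compound 3 gave a number 32.7 percentage points lower from compound 3 to compound 4 (beyond the scatter). Set beside the earlier step, the change lowers the number by a similar amount on both cores: the same change on two cores in this assay, a number 40.4 percentage points lower (beyond the scatter) from compound 1 to compound 2 and a number 32.7 percentage points lower (beyond the scatter) from compound 3 to compound 4, 7.7 percentage points apart, within the scatter of two such steps This is only two pairs, though, and they differ in the place of the group as well as in the core, with dimethylamino two bonds along the chain in one and three bonds along the chain in the other, so they cannot show how much either difference matters on its own, and they say nothing about why the number falls or whether the same would hold on any further core.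

Still open, from the compounds shown here alone, is whether the drop belongs to dimethylamino in particular or would also follow from another group at the end of the chain, such as a primary amine, a morpholine, a hydroxyl or a carboxylic acid. A longer chain on each of the two cores would also help to show whether the size of the step depends on the distance from the ring nitrogen.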